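The source may hold more compounds than are shown below. What is called first, only, known or untested is meant among the compounds shown, and "the series" means these compounds.

In a functional assay on HCT-116 cells (Homo sapiens) for inhibition, read by WST assay, with stated times of 72 h and 2 h (a lower number here means a stronger inhibitor, a higher number a weaker inhibitor), compound 1 (`OC(c1cccs1)c1cc2ccccc2nc1Cl`) gives 69300 nM. Compound 2 (`Clc1nc2ccccc2cc1C(OCc1ccccc1)c1cccs1`) is recorded as "not active" (no number reported), so it stands without a single number. Compound 3 (`Fc1ccc(COC(c2cccs2)c2cc3ccccc3nc2Cl)cc1`) remains unmeasured. The structural change is fluoro in place of hydrogen on an aromatic carbon, or benzyl to 4-fluorobenzyl. No measured step sizes this change. With compound 2 recorded as "not active" (no number reported), no shift beyond the scatter is expected in this assay, and any activity should stay weak. For compound 3, the estimated value is 90000 nM, with an expected range of 40000 nM to 200000 nM.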

Compound 3, half-maximal inhibitory concentration: "not active" (no number reported)
The entry for compound 3 holds no number, and the estimate cannot be compared.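

In this assay compound 2 and compound 3 both stand without a number, so no step can be read between them. Nothing shown bears on this result. As far as these compounds go, whether benzyl to 4-fluorobenzyl shifts activity at all remains open.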